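Adding an Ethyl Branch to the Ether Side Chain

The source may report more compounds than this note shows. Statements on the series, on what has been measured and on what is new or still open speak of the compounds shown alone.

Compound 1 `CC(C)=CC[C@@H](OC(=O)C1CCCCO1)C1=CC(=O)c2c(O)ccc(O)c2C1=O` and compound 2 `COCCO[C@H](CC=C(C)C)C1=CC(=O)c2c(O)ccc(O)c2C1=O` share one core and differ only in the group on the oxygen. In a functional assay on DU-145 cells (Homo sapiens) for cytotoxicity, read by MTT assay (a higher number here means a weaker inhibitor, a lower number a stronger inhibitor), compound 1 gives 24700 nM, and compound 2 gives 43200 nM; the step of a 1.7-fold higher number from compound 1 to compound 2 (0.24 log units; within the scatter) falls within the scatter, so the two values stand level. Compound 3 `CCC(CO[C@H](CC=C(C)C)C1=CC(=O)c2c(O)ccc(O)c2C1=O)OC` differs from compound 2 by ethyl in place of hydrogen on a saturated chain carbon bound to an oxygen on a saturated carbon and a saturated chain carbon. Within the data shown here, no measured step matches this change, and the single measured step was itself small, so compound 3 is expected to show a 1.1-fold lower number from compound 2 to compound 3 (0.03 log units; within the scatter), nothing beyond the scatter. Compound 3 is therefore estimated at 40000 nM, between 15000 nM and 110000 nM.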

Compound 3, half-maximal inhibitory concentration: 45700 nM
For compound 3 the middle estimate is 1.1-fold (0.06 log units) below the measured one, within the range that was stated.
By their numbers in this assay, from the lowest: compounds 1, 2 and 3 (each within the scatter of the next).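

Putting ethyl in place of hydrogen on this saturated chain carbon leaves the reading in this assay level (a 1.1-fold higher number from compound 2 to compound 3 (0.02 log units; within the scatter)), so 2-methoxybutyl and 2-methoxyethyl cannot be told apart here. Set against the (oxan-2-yl)carbonyl group, 2-methoxybutyl also stands level (a 1.9-fold higher number from compound 1 to compound 3 (0.27 log units; within the scatter)), so all three groups on this oxygen read alike. Nothing measured here offers an explanation for this flat result.

On these data alone, whether an amine, a carboxylic acid or a longer chain in place of the ethyl would move the number beyond the scatter stays open.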